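The source may hold more compounds than are shown below. What is called first, only, known or untested is meant among the compounds shown, and "the series" means these compounds.

In this set compound 3 `O=C(C1=C(Nc2ccc(OC(F)(F)F)cc2)C(=O)N(CCCn2ccnc2)C1c1ccc(Br)cc1)c1ccccc1` gives the lowest of the three numbers in a functional assay on NCI-H1299 cells (Homo sapiens) for antiproliferative activity, read by MTT assay, with a stated time of 72 h (a lower number here means a stronger inhibitor, a higher number a weaker inhibitor), namely 11500 nM. Compound 1 `O=C(C1=C(Nc2ccccc2)C(=O)N(CCCn2ccnc2)C1c1ccc(Br)cc1)c1ccccc1` gives 21200 nM in this assay, and compound 2 `O=C(C1=C(Nc2ccc(F)cc2)C(=O)N(CCCn2ccnc2)C1c1ccc(Br)cc1)c1ccccc1` gives 25400 nM. The step of a 1.8-fold lower number from compound 1 to compound 3 (0.27 log units; within the scatter) lies within the scatter, whereas the step of a 2.2-fold lower number from compound 2 to compound 3 (0.34 log units; beyond the scatter) is modest but beyond it; the step of a 1.2-fold higher number from compound 1 to compound 2 (0.08 log units; within the scatter) is again within the scatter. Compound 4 `O=C(C1=C(Nc2cccc(Br)c2)C(=O)N(CCCn2ccnc2)C1c1ccc(Br)cc1)c1ccccc1` differs from compound 3 by 3-bromophenyl in place of 4-(trifluoromethoxy)phenyl on an amine nitrogen. Among the compounds with values here, none of the measured steps involves a bromine substituent, so their bearing on this change is indirect: taken together they show only that exchanging hydrogen, fluoro and trifluoromethoxy on the same phenyl group shifted the numbers in this assay by little, with the largest of them being a modest step. Compound 4 is therefore expected to move only slightly from compound 3, most likely towards a somewhat higher number, with an estimated step of a 1.6-fold higher number from compound 3 to compound 4 (0.19 log units; within the scatter). The estimate for compound 4 in this assay is 18000 nM, with a range from 8000 nM to 40000 nM.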

Compound 4, half-maximal inhibitory concentration: 11500 nM
For compound 4 the middle estimate is 1.6-fold (0.19 log units) above the measured one; measured number inside the range.
By their numbers in this assay, from the lowest: compounds 3, 4, 1 and 2 (each within the scatter of the next, the first and the last beyond it).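

In this assay, 3-bromophenyl in place of 4-(trifluoromethoxy)phenyl on the amine nitrogen gives no change at the digits printed from compound 3 to compound 4 (within the scatter), so this position takes a bromine-bearing phenyl group as readily as the largest group seen there so far, even though the entering group has fewer heavy atoms and no hydrogen-bond acceptor. Bromo in place of hydrogen gives a 1.8-fold lower number from compound 1 to compound 4 (0.27 log units; within the scatter), whereas 3-bromophenyl in place of 4-fluorophenyl gives a 2.2-fold lower number from compound 2 to compound 4 (0.34 log units; beyond the scatter), a modest step that matches in size the one already printed for trifluoromethoxy against fluoro, leaving compound 2 apart from compound 3 and compound 4 while compound 1 lies within the scatter of all three. Nothing available explains why these different groups read alike here.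

The compounds shown leave open whether this result depends on the bromine itself or on its place on the ring. Also open, on these data alone, is whether a carboxylic acid or a dimethylamino group on this phenyl ring, or a cyclohexyl group in its place, would move the number further than any step seen so far.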